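Morpholine to pyrrolidine on the thiourea of compound 1

The compounds below may be only part of what the source reports. "The series", "measured", "known", "first", "only" and "open" are said of these compounds alone.

Compound 1 `N/C(=N\NC(=S)N1CCOCC1)c1ccc(F)cn1` stands at the top of the three numbers measured in a functional assay on A-431 cells (Homo sapiens) for cytotoxicity, read by MTT assay, with a stated time of 72 h, tested at 1 uM (on this read-out lower numbers stand for less inhibition of growth and higher numbers for more inhibition of growth at the one concentration tested), where compound 1 gives 31.8%. Its nearest neighbour is compound 2 `N/C(=N\NC(=S)N1CCOCC1)c1ccccn1`, which in this assay gives 29.2%; the step of a number 2.6 percentage points lower from compound 1 to compound 2 (within the scatter) is within the scatter. Furthest off is compound 3 `Cc1cccc(/C(N)=N/NC(=S)N2CCCC2)n1`, which in this assay gives 21%, a value that lies beyond the scatter from that of compound 1.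

The unmeasured compound 4 `N/C(=N\NC(=S)N1CCCC1)c1ccc(F)cn1` differs from compound 1 in one place: pyrrolidin-1-yl in place of morpholin-4-yl on a thiocarbonyl carbon. Going by the values given here, no measured step swaps these two rings alone. Among the compounds with values here, the only step recorded, a number 2.6 percentage points lower from compound 1 to compound 2 (within the scatter), concerns the aromatic ring and bears on this change only in showing how little one substituent move shifted this assay. Compound 3 carries the pyrrolidinyl ring, but it also differs from compound 1 elsewhere, so only its value can be set beside that of compound 1. On that slim basis the step in this assay is expected to be small, most likely downward but not clearly beyond the scatter.

Compound 4 is therefore estimated at 26% in this assay, with a range from 14% to 38%, meaning an expected step of a number 5.8 percentage points lower from compound 1 to compound 4 (within the scatter).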

Compound 4, percent growth inhibition at one concentration: 50.7%
Estimate against measurement, compound 4: 24.7 percentage points below, outside the stated range (above it).
By their numbers in this assay, from the lowest: compounds 3, 2 and 1 (each within the scatter of the next, the first and the last beyond it); then compound 4.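

Going by these compounds alone, exchanging morpholin-4-yl for pyrrolidin-1-yl on a thiocarbonyl carbon gives a number 18.9 percentage points higher from compound 1 to compound 4 (beyond the scatter) in this assay, so this position responds far more strongly than the earlier compounds could suggest. Within the data shown here, the only earlier single-place step, a number 2.6 percentage points lower from compound 1 to compound 2 (within the scatter), lay on the aromatic ring and stayed small, whereas the ring on the thiocarbonyl carbon now emerges as a place where one change moves growth inhibition clearly, with the six-membered ring holding two hetero atoms giving way to a five-membered ring holding one. No measurement at hand accounts for this gain.

The compounds shown leave open whether ring size or the ring oxygen carries the step, and a piperidin-1-yl group on the same carbon would separate the two. Also open, as far as these compounds go, are how an open-chain dimethylamino group or a piperazin-1-yl group would read at this position, and whether pyrrolidin-1-yl would give a step of similar size on the core with hydrogen in place of fluoro.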